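The source may hold more compounds than are shown below. What is called first, only, known or untested is meant among the compounds shown, and "the series" means these compounds.

Measured compounds:
- compound 1 `COc1cc(/C=C/C(=O)Nc2cc3c(Nc4ccc(F)c(Cl)c4)ncnc3cc2O[C@H]2CCOC2)cc(OC)c1OC`: 4150 nM
- compound 2 `O=C(/C=C/c1ccc(Br)cc1)Nc1cc2c(Nc3ccc(F)c(Cl)c3)ncnc2cc1O[C@H]1CCOC1`: 35300 nM
- compound 3 `O=C(/C=C/c1cc(Br)c(O)c(Br)c1)Nc1cc2c(Nc3ccc(F)c(Cl)c3)ncnc2cc1O[C@H]1CCOC1`: 28800 nM

The three compounds share one core and differ only in the aryl group on the double-bonded chain carbon. In a functional assay on A549 cells (Homo sapiens) for cytotoxicity, read by MTT assay, with a stated time of 72 h (on this read-out higher numbers stand for weaker inhibition and lower numbers for stronger inhibition), compound 3 gives 28800 nM, the second highest of the three numbers; its nearest neighbour is compound 2, separated by a 1.2-fold lower number from compound 2 to compound 3 (0.09 log units; within the scatter), while compound 1 lies furthest away, with a 6.9-fold higher number from compound 1 to compound 3 (0.84 log units; beyond the scatter).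

Compound 4 `O=C(/C=C/c1ccc(F)cc1Cl)Nc1cc2c(Nc3ccc(F)c(Cl)c3)ncnc2cc1O[C@H]1CCOC1` has not been measured. It differs from compound 3 in one place: 2-chloro-4-fluorophenyl in place of 3,5-dibromo-4-hydroxyphenyl on a double-bonded chain carbon bound to a double-bonded chain carbon.

The step that bears most directly on this change is the one between the two halogen-bearing aryl groups, compound 2 to compound 3: a 1.2-fold lower number from compound 2 to compound 3 (0.09 log units; within the scatter). The two larger steps, an 8.5-fold higher number from compound 1 to compound 2 (0.93 log units; beyond the scatter) and a 6.9-fold higher number from compound 1 to compound 3 (0.84 log units; beyond the scatter), both start from the trimethoxy-bearing compound 1 and do not involve compound 4's kind of group. Compound 4 is therefore expected to land close to compounds 2 and 3, with a step of a 1.0-fold higher number from compound 3 to compound 4 (0.02 log units; within the scatter), not beyond the scatter. Compound 4 is estimated at 30000 nM, within 10000 nM to 90000 nM.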

Compound 4, half-maximal inhibitory concentration: 5190 nM
For compound 4 the middle estimate is 5.8-fold (0.76 log units) above the measured one; the measured number lies below the stated range.
By their numbers in this assay, from the lowest: compounds 1 and 4 (each within the scatter of the next); then compounds 3 and 2 (each within the scatter of the next).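

In this assay, swapping to 2-chloro-4-fluorophenyl at this position brings a 5.5-fold lower number from compound 3 to compound 4 (0.74 log units; beyond the scatter) and a 6.8-fold lower number from compound 2 to compound 4 (0.83 log units; beyond the scatter) on the same chain carbon, so carrying halogens does not by itself place an aryl group with compound 2 and compound 3, something those two alone could not show. The same group also brings a 1.3-fold higher number from compound 1 to compound 4 (0.10 log units; within the scatter) in this series, so aryl groups with quite different substituents, 3,4,5-trimethoxyphenyl and 2-chloro-4-fluorophenyl, can give matching numbers here. Nothing measured here explains these differences among the aryl groups.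

Whether the chlorine or the fluorine of 2-chloro-4-fluorophenyl accounts for the difference stays open. An aryl group bearing an amine or a carboxylic acid, or a longer chain in place of the aryl group, also lies outside the compounds shown.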